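Phenylsulfanyl series: methoxy to fluoro step

The source may hold more compounds than are shown below. What is called first, only, known or untested is meant among the compounds shown, and "the series" means these compounds.

Measured so far:
compound 1 `Nc1cc(N)c2nc(-c3ccccc3)c(NCc3ccc(F)cc3)nc2c1` — 8130 nM
compound 2 `COc1ccc(Sc2nc3cc(N)cc(N)c3nc2-c2ccccc2)cc1` — < 100000 nM (a limit)

In a functional assay on OVCAR-4 cells (Homo sapiens) for inhibition, read by sulforhodamine B assay, with a stated time of 48 h (on this read-out higher numbers stand for weaker inhibition of growth and lower numbers for stronger inhibition of growth), compound 1 gives 8130 nM. Compound 2 is known in this assay only as a limit, < 100000 nM. The step that the limit leaves unreadable from compound 1 to compound 2 therefore cannot be sized; the limit of < 100000 nM in this assay, at which 1 of the 2 values shown sits, is all that fixes compound 2, and whether it stands on a par with compound 1 or elsewhere is open.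

Compound 3 `Nc1cc(N)c2nc(-c3ccccc3)c(Sc3ccc(F)cc3)nc2c1` is not yet measured. It differs from compound 2 by fluoro in place of methoxy on an aromatic carbon. For the measured compounds named here, no measured step bears on this change: the only step in the set, a step that the limit leaves unreadable from compound 1 to compound 2, is unreadable and concerns a different group. Going by the values given here, compound 1 gives the sole number, and compound 2 is held only by its limit. Compound 3 is thus estimated at 30000 nM, within 6000 nM to 100000 nM, with a fair chance that this assay again returns only a limit. The implied step that the limit leaves unreadable from compound 2 to compound 3 is expected to be without direction, as nothing measured supports either way.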

Compound 3, concentration for total growth inhibition: 56200 nM
Estimate against measurement, compound 3: 1.9-fold (0.27 log units) below; low and high end bracket the measured number.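

In this assay, (4-fluorophenyl)sulfanyl in place of (4-fluorobenzyl)amino on the same aromatic carbon gives a 6.9-fold higher number from compound 1 to compound 3 (0.84 log units; beyond the scatter). For the compounds shown here, this is the first readable step for a change of this group, and it places a sulfanyl-linked compound on a measured number rather than on a limit, with the read-out moving towards weaker inhibition of growth. The effect of fluoro in place of methoxy on the aromatic carbon cannot be read, nor can the change from compound 1 to compound 2, as compound 2 is held only by a limit: the limit of < 100000 nM in this assay, at which 1 of the 3 values shown sits.

The step from compound 1 to compound 3 changes both the linking atom and the length of the link, so the compounds shown do not separate the two, and a (4-fluorophenyl)amino or a (4-fluorobenzyl)sulfanyl group on that carbon would be needed to do so. As far as these compounds go, how a chloro, a hydroxyl or an amine group in place of fluoro on the six-membered aromatic ring would read in this assay also stays open.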